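One Extra Carbon on a Slowly Cleared Compound

This account rests on a few compounds, and the source may have more. Where it says the series, first, only, none or still open, it means among the compounds named here.

Among the measured compounds shown here, in an ADME assay on liver for metabolic stability, with Liver microsome (Homo sapiens) as the target, read by LC-MS, using microsomes (a lower number here means slower removal, a higher number faster removal of the compound), compound 2 `CC(C)(C)[C@@H](O)C(=O)N1NCC[C@H]1C(=O)NCc1cc(Cl)ccc1-n1cnnn1` gives 15 mL.min-1.g-1, the only true number available so far. Compound 1 `O=C(NCc1cc(Cl)ccc1-n1cnnn1)[C@@H]1CCNN1C(=O)[C@H](O)c1ccccc1` gives < 16 mL.min-1.g-1, which is a limit of the assay and not a number. The measured comparison is therefore a step that the limit leaves unreadable from compound 1 to compound 2, and its size cannot be used. The only other thing known is the limit of < 16 mL.min-1.g-1 in this assay, at which 1 of the 2 values shown sits. Compound 3 `CC(C)(C)C[C@@H](O)C(=O)N1NCC[C@H]1C(=O)NCc1cc(Cl)ccc1-n1cnnn1` differs from compound 2 by neopentyl in place of tert-butyl on a saturated chain carbon bound to a carbonyl carbon and an oxygen on a saturated carbon, so the group simply gains one carbon. For the measured compounds named here, no measured step shows what such a change does in this assay, which leaves no size to carry over, and so no shift beyond the usual scatter is expected. The estimated change is a 1.3-fold higher number from compound 2 to compound 3 (0.12 log units; within the scatter), a slight drift towards faster removal. Compound 3 is expected at 20 mL.min-1.g-1, with an estimated range from 10 mL.min-1.g-1 to 40 mL.min-1.g-1.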

Compound 3, intrinsic clearance in microsomes: 25 mL.min-1.g-1
For compound 3 the middle estimate is 1.3-fold (0.10 log units) below the measured one; the range from low to high includes it.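

This position now has its first readable step in this assay, with a 1.7-fold higher number from compound 2 to compound 3 (0.22 log units; within the scatter), so the one extra carbon of neopentyl does not separate it from tert-butyl in this assay. The comparison with phenyl gives an at least 1.5-fold higher number from compound 1 to compound 3 (0.19 log units; that floor lies within the scatter), and only this floor can be read, so it does not separate neopentyl from phenyl either. Compound 1 is held at a limit and not a number, and its step to compound 2 still cannot be read: the limit of < 16 mL.min-1.g-1 in this assay, at which 1 of the 3 values shown sits.

Going by these compounds, the groups compared at this saturated chain carbon are phenyl, tert-butyl and neopentyl, all built from carbon and hydrogen, so it remains open whether an amine or a carboxylic acid there would shift the number beyond the usual scatter. On these data alone, it is equally open whether a longer chain than neopentyl would do so, and how far compound 1 lies beneath its limit.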